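Changing the sulfonyl aryl group of compound 3

A few compounds are considered here, and "the series" means these few. Any claim that something is new, unique, unknown or untested is made for them only; others in the source may bear on it.

- compound 1 (`Cc1ccc(-c2nn(-c3ccccc3)cc2-c2nc3ccccc3n2S(=O)(=O)c2ccc(Br)cc2)cc1`): > 300000 nM (a limit of the assay)
- compound 2 (`O=S(=O)(c1ccccc1)n1c(-c2cn(-c3ccccc3)nc2-c2ccc(C(F)(F)F)cc2)nc2ccccc21`): 186000 nM
- compound 3 (`Cc1ccc(C)c(S(=O)(=O)n2c(-c3cn(-c4ccccc4)nc3-c3ccc(C(F)(F)F)cc3)nc3ccccc32)c1`): 132000 nM

Going by the values given here, compound 3 gives 132000 nM in an ADME assay on cells (Hepatocyte, Mus musculus) for cytotoxicity, read by MTT assay, with a stated time of 24 h (a higher number here means that more compound is tolerated, a lower number that less compound is tolerated), and holds one of only two true numbers here. The other number lies within the scatter of it (a 1.4-fold lower number from compound 2 to compound 3 (0.15 log units; within the scatter)). Compound 1 gives > 300000 nM and this is a limit of the assay, not a number.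

The unmeasured compound 4 (`O=S(=O)(c1ccc(Br)cc1)n1c(-c2cn(-c3ccccc3)nc2-c2ccc(C(F)(F)F)cc2)nc2ccccc21`) has 4-bromophenyl in place of 2,5-dimethylphenyl on a sulfonyl sulfur. Among the compounds with values here, only one measured step changes the group at this place. It swapped phenyl for 2,5-dimethylphenyl and gave a change no larger than the scatter (a 1.4-fold lower number from compound 2 to compound 3 (0.15 log units; within the scatter)). Compound 1 also carries 4-bromophenyl on a sulfonyl sulfur, but it differs from compound 4 elsewhere as well, so it is only a weak guide. The limit of compound 1 (> 300000 nM) still allows a small upward shift to be expected. No change beyond the scatter is therefore expected in this assay for this swap. The estimated change is small (a 1.4-fold higher number from compound 3 to compound 4 (0.13 log units; within the scatter)). For compound 4 the estimate is 180000 nM with an expected range from 95000 nM to 300000 nM in repeated measurements.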

Compound 4, half-maximal cytotoxic concentration: 167000 nM
The estimate for compound 4 lay 1.1-fold (0.03 log units) above the measured number; low and high end bracket the measured number.
By their numbers in this assay, from the lowest: compounds 3, 4 and 2 (each within the scatter of the next). At a limit, above all of these: compound 1.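

In this assay, 4-bromophenyl on the sulfonyl sulfur gives a step no larger than the scatter (a 1.3-fold higher number from compound 3 to compound 4 (0.10 log units; within the scatter)). Going by these compounds alone, the step that adds only bromo to the plain phenyl ring is just as small (a 1.1-fold lower number from compound 2 to compound 4 (0.05 log units; within the scatter)), so phenyl, 2,5-dimethylphenyl and 4-bromophenyl all lie within the scatter of one another on the same core, which the single earlier step could not show for a ring carrying a halogen. Compound 1 stands at a limit, so the exchange of methyl for trifluoromethyl (an at least 1.7-fold lower number from compound 1 to compound 4 (0.25 log units; that floor lies within the scatter)) gives only a floor, and its true size cannot be read: the limit of > 300000 nM in this assay, at which 1 of the 4 values shown sits.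

Still open, going by these compounds, is whether a ring carrying an amine or a carboxylic acid, or a simple alkyl chain in place of the ring on the sulfonyl sulfur, would move the number beyond the scatter. Also open, on these data alone, is how far methyl and trifluoromethyl differ when both partners of a pair give true numbers rather than a limit.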